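The compounds below may be only part of what the source reports. "The series", "measured", "known", "first", "only" and "open" are said of these compounds alone.

For the measured compounds named here, compound 2 `O=C(Nc1nc(-c2ccccc2)nc2c1nnn2Cc1ccccc1)c1cccc(F)c1` gives 22 nM in an assay (strain Wistar) for displacement of a labelled ligand from adenosine receptor A1 (Rattus norvegicus), read by scintillation counting (a lower number here means a stronger inhibitor, a higher number a weaker inhibitor), the highest of the two numbers so far, while compound 1 `O=C(Nc1nc(-c2ccccc2)nc2c1nnn2Cc1ccccc1)C1CCCCC1` gives 12 nM in this assay. Going by the values given here, the only measured step, a 1.8-fold higher number from compound 1 to compound 2 (0.26 log units; within the scatter), lies within the scatter. Compound 3 `O=C(Nc1nc(-c2ccccc2)nc2c1nnn2Cc1ccccc1)C1CC1` differs from compound 2 by cyclopropyl in place of 3-fluorophenyl on a carbonyl carbon. The step from cyclohexyl to 3-fluorophenyl bears on this change and was small, so a similarly small step is expected in this assay, with no clear direction. Compound 3 is therefore estimated at 20 nM in this assay, within 7 nM to 60 nM, an expected step of a 1.1-fold lower number from compound 2 to compound 3 (0.04 log units; within the scatter).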

Compound 3, inhibition constant: 7.5 nM
Compound 3: the middle estimate sits 2.7-fold (0.43 log units) above what was measured, within the range that was stated.
By their numbers in this assay, from the lowest: compounds 3, 1 and 2 (each within the scatter of the next, the first and the last beyond it).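

With cyclopropyl on the carbonyl carbon, the position shows its first step beyond the scatter in this assay, a 2.9-fold lower number from compound 2 to compound 3 (0.47 log units; beyond the scatter), so replacing 3-fluorophenyl with this group of 3 heavy atoms produces a modest but readable change. Against cyclohexyl, the same group gives a 1.6-fold lower number from compound 1 to compound 3 (0.20 log units; within the scatter), which lies within the scatter, so these two groups cannot be separated here. Nothing shown gives a reason for either step.

On these data alone, what an unsubstituted phenyl would give remains open, so the part played by the fluorine cannot be separated from that of the ring. Also open, as far as these compounds go, is how an open chain such as isopropyl or an amine-bearing ring would fare on this carbonyl carbon.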